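Swapping the amide cap: chloroethyl out, fluorophenyl in

This account rests on a few compounds, and the source may have more. Where it says the series, first, only, none or still open, it means among the compounds named here.

Compound 1, `CN(C)c1ccc(C2CC(c3ccc(-n4ccnc4)cc3)=NN2)cc1`: 7.6%
Compound 2, `CN1CCN(c2ccc(C3=NN(C(=O)c4ccc(F)cc4)C(c4ccc(N(C)C)cc4)C3)cc2)CC1`: 3.5%
Compound 3, `CN(C)c1ccc(C2CC(c3ccc(-n4ccnc4)cc3)=NN2C(=O)CCCl)cc1`: 2.1%

In a functional assay on MDA-MB-231 cells (Homo sapiens) for inhibition, read by sulforhodamine B assay, tested at 10 uM (a lower number here means less inhibition, a higher number more inhibition at the concentration tested (going by the name of the read-out)), compound 3 gives 2.1%, the lowest of the three numbers, yet its gaps to compound 2 and to compound 1 both lie within the usual scatter, so the three cannot be told apart. For the measured compounds named here, the only measured step, a number 5.5 percentage points lower from compound 1 to compound 3 (within the scatter), was itself within the scatter. Compound 4, `CN(C)c1ccc(C2CC(c3ccc(-n4ccnc4)cc3)=NN2C(=O)c2ccc(F)cc2)cc1`, differs from compound 3 by 4-fluorophenyl in place of 2-chloroethyl on a carbonyl carbon. Going by the values given here, no measured step matches this change directly; compound 2, which also carries a (4-fluorophenyl)carbonyl group, gives 3.5%, a number close to that of compound 3. A step no larger than the scatter is therefore expected, a number 1.4 percentage points higher from compound 3 to compound 4 (within the scatter). Compound 4 is estimated at 3.5%, in a range from -5% to 12%.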

Compound 4, a percentage reported as inhibition, at one concentration (the size of the read-out at that concentration, not a potency): 9.4%
For compound 4 the middle estimate is 5.9 percentage points below the measured one, within the range that was stated.
By their numbers in this assay, from the lowest: compounds 3, 2, 1 and 4 (each within the scatter of the next).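

At the carbonyl carbon, the switch from the 2-chloroethyl chain to the 4-fluorophenyl ring leaves this assay unable to separate the two caps (a number 7.3 percentage points higher from compound 3 to compound 4 (within the scatter)). Neither of the other comparisons separates its pair: 1H-imidazol-1-yl in place of 4-methylpiperazin-1-yl (a number 5.9 percentage points higher from compound 2 to compound 4 (within the scatter)), and the (4-fluorophenyl)carbonyl in place of hydrogen on the ring nitrogen (a number 1.8 percentage points higher from compound 1 to compound 4 (within the scatter)). No measurement here offers an explanation for these numbers. On these data alone, whether a longer chain, an amine or a carboxylic acid on this carbonyl would produce a step beyond the scatter remains open.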